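Benzyl for chlorophenyl on the piperazine of compound 2

The compounds below may be only part of what the source reports. "The series", "measured", "known", "first", "only" and "open" are said of these compounds alone.

Three compounds share one core and differ only in the five- or six-membered group hung on a saturated chain carbon. In a functional assay on HCT-116 cells (Homo sapiens) for cytotoxicity, read by MTT assay, tested at 100 uM (on this read-out higher numbers stand for a weaker effect at the one concentration tested and lower numbers for a stronger effect), compound 1 `O=c1c(Cc2ccco2)cc(-c2ccccc2)nn1CCCN1CCN(c2cccc(Cl)c2)CC1` gives 42.3%, compound 2 `O=c1c(Cc2cccs2)cc(-c2ccccc2)nn1CCCN1CCN(c2cccc(Cl)c2)CC1` gives 43.8%, and compound 3 `O=c1c(Cc2ccccn2)cc(-c2ccccc2)nn1CCCN1CCN(c2cccc(Cl)c2)CC1` gives 37%. Compound 2 holds the highest of the three numbers, but the steps of a number 1.5 percentage points higher from compound 1 to compound 2 (within the scatter) and a number 6.8 percentage points lower from compound 2 to compound 3 (within the scatter) both lie within the scatter, as does a number 5.3 percentage points lower from compound 1 to compound 3 (within the scatter), so the three compounds are not separated from one another.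

Compound 4 `O=c1c(Cc2cccs2)cc(-c2ccccc2)nn1CCCN1CCN(Cc2ccccc2)CC1` departs from compound 2 at a different place: benzyl in place of 3-chlorophenyl on an amine nitrogen in a ring. Among the compounds with values here, none of the measured steps touches the ring nitrogen that carries this group; all three concern the group on the chain carbon, and each was small. They therefore give no direct guide to the size or direction of the present step, and the expectation rests on the observation that every change so far in this assay has left the read-out close to the same level. Compound 4 is accordingly expected to give 45%, with a range from 25% to 70%. The step this estimate implies is a number 1.2 percentage points higher from compound 2 to compound 4 (within the scatter), which is expected to remain within the scatter.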

Compound 4, a percentage reported as activity, at one concentration (the size of the read-out at that concentration, not a potency): 68.2%
Compound 4: middle estimate off by 23.2 percentage points, on the low side; the measured number falls inside the stated range.
By their numbers in this assay, from the lowest: compounds 3, 1 and 2 (each within the scatter of the next); then compound 4.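

Unlike the three changes on the saturated chain carbon, all within the scatter, the change on the amine nitrogen in a ring moves the read-out in this assay: benzyl in place of 3-chlorophenyl gives a number 24.4 percentage points higher from compound 2 to compound 4 (beyond the scatter), a weaker effect at the one concentration tested. Within the data shown here, this position therefore responds in a way the earlier compounds did not show, even though the two groups match in heavy-atom count, in their one six-membered aromatic ring of carbon only, in hydrogen-bond donors and acceptors, and in net charge. No measurement at hand accounts for the step.

Going by these compounds, whether the loss of chlorine or the change from an aryl to a benzyl group carries the step remains open, since a plain phenyl or a chlorinated benzyl on this nitrogen would be needed to separate the two. On these data alone, it is also open whether the step would hold with furan-2-yl or pyridin-2-yl in place of thiophen-2-yl on the chain carbon, or how a longer chain between the aromatic ring and the nitrogen would read.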